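A few compounds are considered here, and "the series" means these few. Any claim that something is new, unique, unknown or untested is made for them only; others in the source may bear on it.

Measured compounds:
compound 1 `CCCCCCCCCCCCCCCCCC[C@@H](N)[C@@H](O)CO` gives 21500 nM in a functional assay on Colon 26 cells (Mus musculus) for inhibition; on this read-out lower numbers stand for stronger inhibition and higher numbers for weaker inhibition;
compound 2 `CCCCCCCCCCCCCC[C@H](N)[C@H](O)CO` gives 3680 nM;
compound 3 `CCCCCCCCCCCCCC[C@@H](N)[C@@H](O)CO` gives 3580 nM.

Compound 2 stands second highest of the three numbers, level with compound 3 and well apart from compound 1. The unmeasured compound 4 `CCCCCCCCCCCCCCCCCC[C@H](N)[C@H](O)CO` differs from compound 2 by butyl in place of hydrogen on a saturated chain carbon, ten or more bonds along the chain from an amine nitrogen. For the measured compounds named here, two measured steps bear on this. The step of a 6.0-fold lower number from compound 1 to compound 3 (0.78 log units; beyond the scatter) is the same change run backwards: removing the butyl lowered the number clearly. The step of a 1.0-fold lower number from compound 2 to compound 3 (0.01 log units; within the scatter) shows the mirror-image pair moving nothing, because of the fact that compounds 2 and 3 differ only in the configuration as drawn. Adding the butyl to compound 2 is therefore expected to raise the number, close to where compound 1 sits; the expected step is a 5.4-fold higher number from compound 2 to compound 4 (0.74 log units; beyond the scatter). Compound 4 is thus estimated at 20000 nM, with a range from 7000 nM to 60000 nM.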

Compound 4, half-maximal inhibitory concentration: 3970 nM
The estimate for compound 4 lay 5.0-fold (0.70 log units) above the measured number; the whole stated range lies above it.
By their numbers in this assay, from the lowest: compounds 3, 2 and 4 (each within the scatter of the next); then compound 1.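

In this assay, butyl in place of hydrogen on this saturated chain carbon leaves the number level in the configuration of compound 2, with a 1.1-fold higher number from compound 2 to compound 4 (0.03 log units; within the scatter). The same change therefore reads differently on the two mirror-image series: the same change on two cores in this assay, a 6.0-fold lower number (0.78 log units; beyond the scatter) from compound 1 to compound 3 and a 1.1-fold lower number (0.03 log units; within the scatter) from compound 4 to compound 2, 5.6-fold (0.75 log units) apart, beyond the scatter of two such steps. Mirror images that stood level without the butyl now stand apart, with a 5.4-fold lower number from compound 1 to compound 4 (0.73 log units; beyond the scatter), and configuration is the only difference: the fact that compounds 1 and 4 differ only in the configuration as drawn.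

From the compounds shown here alone, it remains open how a propyl or an octyl group at this place would behave. Going by these compounds, it also remains open how forms with only one of the two stereocentres inverted would compare.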